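Swapping a benzyl group for a hydroxyethyl chain

The source may hold more compounds than are shown below. What is called first, only, known or untested is meant among the compounds shown, and "the series" means these compounds.

Compound 1 `C=CCn1c(=N)sc2cc(OC(F)(F)F)ccc21`: in a functional assay on the whole organism with Rattus norvegicus as the target (a higher number here means that more compound is needed for the effect, a lower number that less compound is needed), compound 1 gives 7 mg/kg.
Compound 2 `N=c1sc2cc(OC(F)(F)F)ccc2n1Cc1ccccc1`: in this assay compound 2 shows only the limit > 10 mg/kg.

Compound 2 therefore has no exact number, only a limit, as the evidence the limit of > 10 mg/kg in this assay, at which 1 of the 2 values shown sits, records. Among the compounds with values here, the single measured step, an at least 1.4-fold higher number from compound 1 to compound 2 (0.15 log units; that floor lies within the scatter), is the only comparison available, and it sits at the floor of the scatter, so it says little about direction. Compound 3 `N=c1sc2cc(OC(F)(F)F)ccc2n1CCO` differs from compound 2 by hydroxymethyl in place of phenyl on a saturated chain carbon bound to an aromatic nitrogen. Within the data shown here, no measured step shows hydroxymethyl entering in place of phenyl, so the expectation for compound 3 rests on the limit of compound 2 alone and is wide. Compound 3 is estimated to give 10 mg/kg in this assay, within 4 mg/kg to 30 mg/kg, meaning an expected step of a number no higher from compound 2 to compound 3 (the limit leaves the size open).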

Compound 3, dose for half-maximal effect: 8 mg/kg
Compound 3: the middle estimate sits 1.3-fold (0.10 log units) above what was measured, within the range that was stated.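

The clearest reading comes from the two measured numbers: a 1.1-fold higher number from compound 1 to compound 3 (0.06 log units; within the scatter). In this assay, then, hydroxymethyl and vinyl cannot be told apart at this place on the chain, even though hydroxymethyl brings a hydrogen-bond donor and a hydrogen-bond acceptor that vinyl lacks. The other new comparison, an at least 1.2-fold lower number from compound 2 to compound 3 (0.09 log units; that floor lies within the scatter), gives only a floor, so it does not show that replacing benzyl with 2-hydroxyethyl changes the dose needed, and compound 2 remains a limit rather than a number: the limit of > 10 mg/kg in this assay, at which 1 of the 3 values shown sits.

As far as these compounds go, how far compound 2 truly stands from the other two compounds remains open. Also unknown is whether an amine or a carboxylic acid in place of the hydroxymethyl, or a longer chain, would fall in the same range.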